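Chain length and branching at the amide nitrogen in rat

This account rests on a few compounds, and the source may have more. Where it says the series, first, only, none or still open, it means among the compounds named here.

Measured compounds:
compound 1 `COc1cccc([C@H]2O[C@H](CC(=O)N[C@@H](C)C(=O)O)C(=O)N(CC(C)(C)CO)c3ccc(Cl)cc32)c1OC`: 14%
compound 2 `COc1cccc([C@H]2O[C@H](CC(=O)N[C@H](C)C(=O)O)C(=O)N(CC(C)(C)CO)c3ccc(Cl)cc32)c1OC`: 31%
compound 3 `COc1cccc([C@H]2O[C@H](CC(=O)NCCC(=O)O)C(=O)N(CC(C)(C)CO)c3ccc(Cl)cc32)c1OC`: 19%

In a functional assay on the whole organism for inhibition, with Rattus norvegicus as the target, at a dose of 10 mg/kg by the oral route (on this read-out higher numbers stand for more inhibition at the one dose given (going by the name of the read-out) and lower numbers for less inhibition), compound 3 gives 19%, which places it second highest of the three numbers. Its nearest neighbour is compound 1 with 14%, a gap within the scatter; the furthest is compound 2 with 31%, where a number 12 percentage points lower from compound 2 to compound 3 (beyond the scatter).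

Compound 4 `COc1cccc([C@H]2O[C@H](CC(=O)NC(CC(C)C)C(=O)O)C(=O)N(CC(C)(C)CO)c3ccc(Cl)cc32)c1OC` is not yet measured. It differs from compound 3 in one place: 1-carboxy-3-methylbutyl in place of 2-carboxyethyl on an amide-type nitrogen.

For the measured compounds named here, two measured steps touch the same nitrogen and therefore bear on this change. One is a number 5 percentage points higher from compound 1 to compound 3 (within the scatter), the other a number 12 percentage points lower from compound 2 to compound 3 (beyond the scatter). The two 1-carboxyethyl compounds themselves sit apart, since a number 17 percentage points higher from compound 1 to compound 2 (beyond the scatter), a difference that rests on (the fact that compounds 1 and 2 differ only in the configuration as drawn). Compound 4 again carries a 1-carboxyalkyl group on that nitrogen, but with no configuration drawn, so a value close to the middle of compounds 1 and 2 is expected. For compound 4 the estimate is 22%, with a range from 8% to 38%, which means an expected step of a number 3 percentage points higher from compound 3 to compound 4 (within the scatter), likely within the scatter.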

Compound 4, a percentage reported as inhibition, in the whole organism at one dose (the size of the read-out at that dose, not a potency): 14%
Compound 4: the middle estimate sits 8 percentage points above what was measured, and the stated range covers the measured number.
By their numbers in this assay, from the lowest: compounds 1, 4 and 3 (each within the scatter of the next); then compound 2.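

In this assay, putting 1-carboxy-3-methylbutyl in place of 2-carboxyethyl on the amide-type nitrogen leaves the read-out inside the usual scatter, the step being a number 5 percentage points lower from compound 3 to compound 4 (within the scatter). Compared with the 1-carboxyethyl compounds, the result splits: the step is no change at the digits printed from compound 1 to compound 4 (within the scatter), but a number 17 percentage points lower from compound 2 to compound 4 (beyond the scatter). Compound 2 is therefore the only one of the four set apart from all the others by more than the scatter, and what separates it from compound 1 is stereochemical alone: the fact that compounds 1 and 2 differ only in the configuration as drawn

The 1-carboxy-3-methylbutyl group of compound 4 carries no drawn configuration, so the compounds shown leave open how each of its single forms would read. They also leave open what an amine in place of the carboxylic acid on this chain would give.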